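Replacing the chain on the aromatic nitrogen

The source may hold more compounds than are shown below. What is called first, only, known or untested is meant among the compounds shown, and "the series" means these compounds.

compound 1 `CCCCCn1nc(C(=O)N[C@H]2COc3ccccc3N(C)C2=S)nc1Cc1ccccc1`: in a toxicity assay on HT-29 cells (Homo sapiens) for cytotoxicity (a lower number here means that less compound is tolerated, a higher number that more compound is tolerated), compound 1 gives > 100000 nM, which is a limit of the assay, not a number.
compound 2 `COCCn1nc(C(=O)N[C@H]2COc3ccccc3N(C)C2=S)nc1Cc1ccccc1`: in this assay compound 2 gives > 100000 nM, again a limit of the assay.
compound 3 `CN1C(=S)[C@@H](NC(=O)c2nc(Cc3ccccc3)n(C3CCCCCC3)n2)COc2ccccc21`: in this assay compound 3 gives > 100000 nM, again a limit of the assay.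

Compound 2 stands at the assay limit, and so do the two other values shown: all three sit at the limit of > 100000 nM in this assay, at which 3 of the 3 values shown sit. The three steps among these compounds, a step that the two limits leave unreadable from compound 1 to compound 2, a step that the two limits leave unreadable from compound 1 to compound 3 and a step that the two limits leave unreadable from compound 2 to compound 3, are therefore unreadable; two limits cannot show how large a step is or which way it points. They all concern the group on an aromatic nitrogen, which is also where compound 4 `CN1C(=S)[C@@H](NC(=O)c2nc(Cc3ccccc3)n(CC3CCOC3)n2)COc2ccccc21` differs from compound 2: oxolan-3-yl in place of methoxymethyl on a saturated chain carbon bound to an aromatic nitrogen. Every measured step bears on this change, yet none of them gives a size, so there is no readable basis for a direction. Since compound 2 gives > 100000 nM and the related chain changes all stayed at the limit, the expected step is a step that the limit leaves unreadable from compound 2 to compound 4, within scatter. For compound 4 the estimate is 150000 nM, with a range from 50000 nM to 400000 nM, most likely reported again only as a limit.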

Compound 4, half-maximal cytotoxic concentration: > 100000 nM
Compound 4 was reported as a limit; the forecaster's own chance of this, stated with the estimate: 85%; the middle value does not contradict the limit.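

Compound 4 gives > 100000 nM in this assay, which is a limit of the assay and not a number, so its steps from compound 1, compound 2 and compound 3 cannot be read: the limit of > 100000 nM in this assay, at which 4 of the 4 values shown sit.

The compounds shown leave open what concentration of each is cytotoxic, and whether changing the group on the aromatic nitrogen alters it at all.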